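Swapping Chloro for Bromo on a Weak Inhibitor

This account rests on a few compounds, and the source may have more. Where it says the series, first, only, none or still open, it means among the compounds named here.

Compound 1 (`O=C1CSC(N2N=C(c3ccc(Cl)cc3)CC2c2cccc3ccccc23)=N1`) sits among three measured compounds whose numbers are hard to tell apart. In a functional assay on HepG2 cells (Homo sapiens) for inhibition, read by CCK-8 assay, with a stated time of 48 h (on this read-out higher numbers stand for weaker inhibition and lower numbers for stronger inhibition), compound 1 gives 16500 nM, compound 3 (`Clc1ccc(C2=NN(C3=NC(c4ccccc4)CS3)C(c3cccc4ccccc34)C2)cc1`) gives 18700 nM and compound 2 (`Fc1ccc(C2=NN(C3=NC(c4ccccc4)CS3)C(c3ccc4ccccc4c3)C2)cc1`) gives 26500 nM. The gaps from compound 1 to the other two lie within the scatter of repeated measurements.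

Compound 4 (`O=C1CSC(N2N=C(c3ccc(Br)cc3)CC2c2cccc3ccccc23)=N1`) keeps the core of compound 1 and alters a single substituent: bromo in place of chloro on an aromatic carbon. This is bromo in place of chloro on an aromatic carbon, turning a 4-chlorophenyl into a 4-bromophenyl.

For the measured compounds named here, no measured pair shows this exchange directly. Going by the values given here, the one measured step that bears on it is indirect: a 1.1-fold higher number from compound 1 to compound 3 (0.05 log units; within the scatter). That much larger replacement leaves the chloro untouched, and it stays within the scatter. Compound 2 and compound 3 carry different halogens but also differ elsewhere, so their values cannot isolate a halogen exchange.

With so small a change, no shift beyond the scatter is expected in this assay. The expected step is a 1.1-fold lower number from compound 1 to compound 4 (0.03 log units; within the scatter). For compound 4 the estimated value is 15500 nM, with an expected range from 8000 nM to 29000 nM.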

Compound 4, half-maximal inhibitory concentration: 13400 nM
Estimate against measurement, compound 4: 1.2-fold (0.06 log units) above; the measured number falls inside the stated range.
By their numbers in this assay, from the lowest: compounds 4, 1, 3 and 2 (each within the scatter of the next).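

Compound 1 and compound 4 form the only pair shown that isolates the halogen on an aromatic carbon of this six-membered aromatic ring, para to a large group. In this assay, the exchange gives a 1.2-fold lower number from compound 1 to compound 4 (0.09 log units; within the scatter), so within this read-out, bromo and chloro cannot be told apart at this position on the core of compound 1. The data shown offer no measurement that could explain this result.

From the compounds shown here alone, with only chloro and bromo compared directly on this core, it remains open whether the position accepts a clearly different group, such as a methoxy group, an amine or a carboxylic acid, with a similar result in this assay. Going by these compounds, it is also open whether the same exchange would read alike on the core of compound 3, where the chloro-bearing ring sits on a different shared framework, since one pair cannot establish a pattern across other cores.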